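The source may report more compounds than this note shows. Statements on the series, on what has been measured and on what is new or still open speak of the compounds shown alone.

Values in an assay on C3H 10T1/2 cells for inhibition of Sonic hedgehog protein (Mus musculus), read by a luciferase reporter (on this read-out higher numbers stand for weaker inhibition and lower numbers for stronger inhibition), for the three measured compounds:

compound 1, `Cc1nc(C(F)(F)F)ccc1C(=O)Nc1ccc(Cl)c(-n2cccn2)c1`: 450 nM
compound 2, `Cc1nc(C(F)(F)F)ccc1C(=O)Nc1ccc(Cl)c(-c2ncccn2)c1`: 8000 nM
compound 3, `Cc1ccc(C(=O)Nc2ccc(Cl)c(-c3ccccn3)c2)c(C)n1`: 130 nM

Compound 3 gives the lowest number of the three; compound 1 sits above it and compound 2 well above it, both gaps beyond the usual scatter. For the measured compounds named here, the single step measured, an 18-fold higher number from compound 1 to compound 2 (1.25 log units; beyond the scatter), concerns the group on the aromatic carbon of the shared core and leaves the acyl side untouched, so it does not bear directly on the step considered here.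

Compound 4, `O=C(Nc1ccc(Cl)c(-c2ccccn2)c1)c1ccc(Cl)cc1`, differs from compound 3 on the other side of the amide: 4-chlorophenyl in place of 2,6-dimethylpyridin-3-yl on a carbonyl carbon. Going by the values given here, no measured pair changes this part of the molecule, so the expectation for compound 4 rests on no direct precedent and carries a wide range. A moderate loss is taken as the more likely outcome, without any step from the measured compounds to anchor it.

For compound 4 in this assay the estimate is 400 nM, with a range from 100 nM to 2000 nM. The step this estimate means, a 3.1-fold higher number from compound 3 to compound 4 (0.49 log units; beyond the scatter), is an expected rise in the number, with the uncertainty covering an outcome within the scatter as well.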

Compound 4, half-maximal inhibitory concentration: 1500 nM
For compound 4 the middle estimate is 3.8-fold (0.57 log units) below the measured one; the measured number falls inside the stated range.
By their numbers in this assay, from the lowest: compound 3; then compound 1; then compound 4; then compound 2.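

In this assay, for the compounds shown here, the acyl side of the amide proves to be a place where the read-out responds strongly: 4-chlorophenyl in place of 2,6-dimethylpyridin-3-yl on a carbonyl carbon gives a 12-fold higher number from compound 3 to compound 4 (1.06 log units; beyond the scatter) and so a large step, which the earlier compounds could not show, as their only single-place step concerned the group on an aromatic carbon. This one change takes out the ring nitrogen and both methyl groups and brings in chlorine, so the data cannot divide the rise among these parts. Nothing measured here accounts for the step.

Still open, from the compounds shown here alone, is how a plain phenyl or a 2-methylpyridin-3-yl on the same carbonyl carbon would read. Also open, going by these compounds, is whether an amine or a carboxylic acid on this ring would move the number, and whether the step carries over to the 1H-pyrazol-1-yl compounds.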